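The source may hold more compounds than are shown below. What is called first, only, known or untested is meant among the compounds shown, and "the series" means these compounds.

Measured compounds:
- Compound 1 `O=C(NO)c1cccc(NCCOc2ccc3cc2COC/C=C/COCc2cccc(c2)-c2ccnc(n2)N3)c1`. In a functional assay on MDA-MB-231 cells (Homo sapiens) for antiproliferative activity, read by MTT assay, with a stated time of 72 h (on this read-out lower numbers stand for stronger inhibition and higher numbers for weaker inhibition), compound 1 gives > 50000 nM, which is a limit of the assay rather than a number.
- Compound 2 `O=C(O)CCCCCCOc1ccc2cc1COC/C=C/COCc1cccc(c1)-c1ccnc(n1)N2`. In this assay compound 2 gives 12000 nM.
- Compound 3 `O=C(O)c1cccc(NCCOc2ccc3cc2COC/C=C/COCc2cccc(c2)-c2ccnc(n2)N3)c1`. In this assay compound 3 gives 21400 nM.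

Among the two numbers, compound 2 has the lowest, but the nearest one, that of compound 3, lies within the scatter: a 1.8-fold higher number from compound 2 to compound 3 (0.25 log units; within the scatter). The third value is the limit of compound 1 (the limit of > 50000 nM in this assay, at which 1 of the 3 values shown sits).

Compound 4 `O=C(O)CCCCCCCOc1ccc2cc1COC/C=C/COCc1cccc(c1)-c1ccnc(n1)N2` differs from compound 2 in one place: carboxymethyl in place of carboxy on a saturated chain carbon, six bonds along the chain from an oxygen on an aromatic ring. The chain carrying the acid is longer by one link.

Going by the values given here, none of the measured steps changes chain length alone. The steps from compound 1 swap the whole group at the chain end, an at least 4.1-fold lower number from compound 1 to compound 2 (0.61 log units; beyond the scatter) and an at least 2.3-fold lower number from compound 1 to compound 3 (0.36 log units; beyond the scatter), and start from a limit, so they say little about a single added link. The step of a 1.8-fold higher number from compound 2 to compound 3 (0.25 log units; within the scatter), which replaces one acid-bearing chain with another, stays within the scatter. On this basis no step beyond the scatter is expected in this assay: the expected step is no change at the digits printed from compound 2 to compound 4 (within the scatter). Compound 4 is therefore estimated at 12000 nM, with a range from 5000 nM to 30000 nM.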

Compound 4, half-maximal inhibitory concentration: 17100 nM
Compound 4: the middle estimate sits 1.4-fold (0.15 log units) below what was measured; measured number inside the range.
By their numbers in this assay, from the lowest: compounds 2, 4 and 3 (each within the scatter of the next). At a limit, above all of these: compound 1.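

Lengthening the chain by one link, with carboxymethyl in place of carboxy six bonds along the chain from an oxygen on an aromatic ring, is the first change here that alters chain length alone, and in this assay it gives a 1.4-fold higher number from compound 2 to compound 4 (0.15 log units; within the scatter), so this single link does not separate the two acids. The saturated chain and the aromatic chain also cannot be told apart, since 5-carboxypentyl in place of (3-carboxyphenyl)amino gives a 1.3-fold lower number from compound 3 to compound 4 (0.10 log units; within the scatter). The remaining step, an at least 2.9-fold lower number from compound 1 to compound 4 (0.46 log units; beyond the scatter), lies beyond the scatter, but it starts from a limit rather than a number: the limit of > 50000 nM in this assay, at which 1 of the 4 values shown sits.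

The compounds shown leave open whether a much longer or a shorter chain ending in the same carboxylic acid would move the number beyond the scatter, as only one added link is covered here. They also leave open whether the acid itself matters, which an amine, a methyl ester or a hydroxycarbamoyl group at the end of the same saturated chain could test.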